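The source may hold more compounds than are shown below. What is called first, only, known or untested is meant among the compounds shown, and "the series" means these compounds.

In an assay on cells for inhibition of ubiquitin carboxyl-terminal hydrolase 8 (Homo sapiens), read by fluorescence, with a stated time of 30 min (on this read-out higher numbers stand for weaker inhibition and lower numbers for stronger inhibition), three compounds of this series have been measured. Compound 1 `Cc1n[nH]c(C)c1Oc1c(O)cc(O)c2c(=O)cc(-c3ccc(N4CCN(c5ccccn5)CC4)cc3)oc12` gives 1200 nM in this assay. Compound 2 `COc1c(O)cc(O)c2c(=O)cc(-c3ccc(N4CCN(C=O)CC4)cc3)oc12` gives 2200 nM in this assay, and that number lies within the usual scatter of the number for compound 1. Compound 3 `O=c1cc(-c2ccc(N3CCCNCC3)cc2)oc2c(OC3CCCCC3)c(O)cc(O)c12` gives 16200 nM in this assay, a number beyond the scatter from compound 1. Among the three numbers that of compound 1 is the lowest, separated from compound 2 by less than the scatter and from compound 3 by more.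

Compound 4 `CCN1CCN(c2ccc(-c3cc(=O)c4c(O)cc(O)c(Oc5c(C)n[nH]c5C)c4o3)cc2)CC1` has not yet been measured. It differs from compound 1 in one place: ethyl in place of pyridin-2-yl on an amine nitrogen in a ring. Going by the values given here, no measured pair in the set isolates this change, since compound 2 differs from compound 1 elsewhere as well. What compound 1 with 1200 nM and compound 2 with 2200 nM show is that the two are within the scatter of each other. The step of a 1.7-fold higher number from compound 1 to compound 4 (0.22 log units; within the scatter) is therefore expected to be small, a mild weakening at most and possibly none beyond the scatter. Compound 4 is estimated to give 2000 nM in this assay, within a range from 800 nM to 5000 nM.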

Compound 4, half-maximal inhibitory concentration: 15500 nM
The estimate for compound 4 lay 7.8-fold (0.89 log units) below the measured number, and the stated range ends below it.
By their numbers in this assay, from the lowest: compounds 1 and 2 (each within the scatter of the next); then compounds 4 and 3 (each within the scatter of the next).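

In this assay the group on this amine nitrogen in a ring clearly matters: going from 4-(pyridin-2-yl)piperazin-1-yl to 4-ethylpiperazin-1-yl gives a 13-fold higher number from compound 1 to compound 4 (1.11 log units; beyond the scatter) and thus a large weakening of inhibition. Going by these compounds alone, this is the first pair in the set that isolates a single change, and it shows that ethyl cannot replace pyridin-2-yl on the shared core without a loss beyond the scatter. Nothing available bears on the reason for this step.

The pair cannot separate the contribution of the aromatic ring from that of its ring nitrogen, since both leave together. The compounds shown also leave open how phenyl, which keeps a six-membered aromatic ring without the hetero atom, or pyridin-3-yl, which moves the ring nitrogen, would stand on this nitrogen.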